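This account rests on a few compounds, and the source may have more. Where it says the series, first, only, none or still open, it means among the compounds named here.

Measured in a functional assay on K562 cells (Homo sapiens) for cytotoxicity, read by MTT assay, with a stated time of 24 h; on this read-out higher numbers stand for weaker inhibition and lower numbers for stronger inhibition:
Compound 1 `COc1cc(/C=C2\CN(C)C/C(=C\c3ccccc3F)C2=O)cc(OC)c1`: 6320 nM
Compound 2 `CN1C/C(=C\c2cccc([N+](=O)[O-])c2)C(=O)/C(=C/c2ccccc2F)C1`: 3890 nM
Compound 3 `COc1cc(/C=C2\CN(C)C/C(=C\c3ccc(Br)cc3)C2=O)cc(OC)c1`: 7420 nM

Compound 3, at 7420 nM, lies within the scatter of both other compounds, so the three values do not separate it from them. Compound 4 `COc1cc(/C=C2\CN(C)C/C(=C\c3ccc(Cl)c(Cl)c3)C2=O)cc(OC)c1` has 3,4-dichlorophenyl in place of 4-bromophenyl on a double-bonded chain carbon bound to a double-bonded ring carbon. Among the compounds with values here, one measured step bears on this place: a 1.2-fold higher number from compound 1 to compound 3 (0.07 log units; within the scatter), where 4-bromophenyl replaced 2-fluorophenyl. Within the data shown here, that step stayed within the scatter, and it is the only guide, so no shift beyond the scatter is expected in this assay. The expected change is a 1.2-fold lower number from compound 3 to compound 4 (0.09 log units; within the scatter). For compound 4 the estimated value is 6000 nM, with an expected range of 2800 nM to 12000 nM.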

Compound 4, half-maximal inhibitory concentration: 9490 nM
Beside the measured number, compound 4's estimate is 1.6-fold (0.20 log units) below it; measured number inside the range.
By their numbers in this assay, from the lowest: compounds 2, 1, 3 and 4 (each within the scatter of the next, the first and the last beyond it).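

In this assay, 3,4-dichlorophenyl in place of 4-bromophenyl gave a 1.3-fold higher number from compound 3 to compound 4 (0.11 log units; within the scatter) and 3,4-dichlorophenyl in place of 2-fluorophenyl gave a 1.5-fold higher number from compound 1 to compound 4 (0.18 log units; within the scatter) at this position. Compounds 1, 3 and 4 therefore show that this read-out does not separate these three halogen-bearing phenyl groups, even with the heavy-atom count rising from 7 to 8 between the last two. No evidence here bears on these results. The compounds shown leave open whether an amine or a carboxylic acid on this phenyl ring would shift the number beyond the scatter.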